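This account rests on a few compounds, and the source may have more. Where it says the series, first, only, none or still open, it means among the compounds named here.

Working notes on the series.

In an assay for inhibition of Dihydrofolate reductase (Gallus gallus) (a lower number here means a stronger inhibitor, a higher number a weaker inhibitor), compound 1 `Nc1ncc(Cc2ccccc2O)c(N)n1` gives 89100 nM. Compound 2 `Nc1ncc(Cc2ccccc2Br)c(N)n1` gives 12300 nM in this assay. Among the measured compounds shown here, the only measured step in this assay is a 7.2-fold lower number from compound 1 to compound 2 (0.86 log units; beyond the scatter). Within the two numbers shown, compound 2 therefore stands with the lower one, and compound 1 is its only neighbour, with a higher number beyond the scatter.

Compound 3 `CCCCCCOc1ccccc1Cc1cnc(N)nc1N` is not yet measured. Its difference from compound 2 is hexyloxy in place of bromo on an aromatic carbon. For the measured compounds named here, no measured pair shows a hexyloxy group anywhere, so the step from compound 1 to compound 2 bears on it only insofar as it shows that the substituent at this position matters for this assay, and by a modest amount. On that basis a step of similar size is expected, its direction uncertain, toward a somewhat lower number: a 3.1-fold lower number from compound 2 to compound 3 (0.49 log units; beyond the scatter). For compound 3 the estimate in this assay is 4000 nM, with a range from 800 nM to 20000 nM.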

Compound 3, inhibition constant: 7940 nM
Compound 3: middle estimate off by 2.0-fold (0.30 log units), on the low side, and the stated range covers the measured number.
By their numbers in this assay, from the lowest: compounds 3 and 2 (each within the scatter of the next); then compound 1.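

In this assay, hexyloxy in place of bromo gives a 1.5-fold lower number from compound 2 to compound 3 (0.19 log units; within the scatter), so at this position on the aromatic ring the two groups cannot be told apart, despite the much larger chain. Hexyl in place of the hydrogen on the oxygen of compound 1 gives an 11-fold lower number from compound 1 to compound 3 (1.05 log units; beyond the scatter), which shows that the free hydroxy is not needed here: compound 2 and compound 3 both lack it, and both stand apart from compound 1 beyond the scatter. No measurement at hand explains either step.

With a single ether chain, the series cannot show whether chain length matters at this position. Still open, on these data alone, is whether methoxy, a chain longer than hexyl, or an amine here would stay level with compound 2 and compound 3.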